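A few compounds are considered here, and "the series" means these few. Any claim that something is new, unique, unknown or untested is made for them only; others in the source may bear on it.

Going by the values given here, compound 1 `COc1ccccc1N1CCN(CCn2nc(-n3cnc4ccccc43)ccc2=O)CC1` gives 33 nM in an assay on cell membranes from brain for binding affinity to Adrenergic receptor alpha-1 (Rattus norvegicus), read by radioligand binding (a higher number here means a weaker inhibitor, a lower number a stronger inhibitor), the higher of the two numbers measured so far; compound 2 `COc1ccccc1N1CCN(CCCCCn2nc(-n3cnc4ccccc43)ccc2=O)CC1` gives 3.1 nM in this assay, a gap that lies beyond the scatter. Compound 3 `O=c1ccc(-n2cnc3ccccc32)nn1CCN1CCN(c2ccccc2Cl)CC1` differs from compound 1 by chloro in place of methoxy on an aromatic carbon. Among the compounds with values here, no measured pair shows this change, so nothing here fixes its size. The expected step from compound 1 to compound 3, a 1.8-fold higher number from compound 1 to compound 3 (0.26 log units; within the scatter), is small, toward a higher number or none beyond the scatter. Compound 3 is thus estimated at 60 nM in this assay, within 15 nM to 250 nM.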

Compound 3, inhibition constant: 70.4 nM
The estimate for compound 3 lay 1.2-fold (0.07 log units) below the measured number; the measured number falls inside the stated range.
By their numbers in this assay, from the lowest: compound 2; then compound 1; then compound 3.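

Chloro in place of methoxy on an aromatic carbon, ortho to a large group, gives a 2.1-fold higher number from compound 1 to compound 3 (0.33 log units; beyond the scatter) in this assay. This position therefore responds to the change, but the step is modest, and the series keeps measurable affinity without the methoxy group. Nothing available explains the step.

On these data alone, whether a methyl, hydroxy or amine at this position would move the number further remains open. So does whether the same change gives a step of similar size on the longer chain of compound 2.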